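This account rests on a few compounds, and the source may have more. Where it says the series, first, only, none or still open, it means among the compounds named here.

In a functional assay on B16-F10 cells (Mus musculus) for antiproliferative activity, read by MTT assay, with a stated time of 72 h (on this read-out higher numbers stand for weaker inhibition and lower numbers for stronger inhibition), the measured compounds stand as follows:

Compound 1 `CSc1nc(-c2ccc(S(N)(=O)=O)cc2)n(-c2ccc(Cl)cc2)n1`: 32300 nM
Compound 2 `CS(=O)(=O)c1ccc(-c2nc(SCCOC(=O)/C=C/c3ccc(O)c(O)c3)nn2-c2ccccc2)cc1`: 15000 nM
Compound 3 `CS(=O)(=O)c1ccc(-c2nc(SCCCOC(=O)/C=C/c3ccc(O)c(O)c3)nn2-c2ccc(Br)cc2)cc1`: 13100 nM

Compound 3 has the lowest number of the three. Compound 2 sits within the scatter of it, so the two cannot be told apart, while compound 1 lies beyond the scatter with a higher number. Compound 4 `CS(=O)(=O)c1ccc(-c2nc(SCCCOC(=O)/C=C/c3ccc(O)c(O)c3)nn2-c2ccc(F)cc2)cc1` has not yet been measured. It differs from compound 3 in one place: fluoro in place of bromo on an aromatic carbon. Within the data shown here, no measured pair shows this change here, so in this assay no step beyond the scatter is expected in either direction. Compound 4 is estimated at 15000 nM, with a range from 6000 nM to 40000 nM. That estimate means an expected step of a 1.1-fold higher number from compound 3 to compound 4 (0.06 log units; within the scatter) that stays within the scatter.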

Compound 4, half-maximal inhibitory concentration: 10400 nM
Compound 4: middle estimate off by 1.4-fold (0.16 log units), on the high side; the measured number falls inside the stated range.
By their numbers in this assay, from the lowest: compounds 4, 3 and 2 (each within the scatter of the next); then compound 1.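

Among these compounds, replacing bromo with fluoro on the aromatic carbon gives the first direct comparison at this position: in this assay the change produces a 1.3-fold lower number from compound 3 to compound 4 (0.10 log units; within the scatter) and so leaves the two compounds indistinguishable. Among the compounds shown here, at this position of the shared core, then, the two halogens cannot be told apart in this cell read-out, something no earlier pair could show. No measured information is available to explain this result.

Going by these compounds, whether a methoxy group or an amine at the same position would shift the number remains open. So does whether a longer chain in place of the present one would do so.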